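The compounds below may be only part of what the source reports. "The series", "measured", "known", "first", "only" and "open" are said of these compounds alone.

In a functional assay on MCF7 cells (Homo sapiens) for cytotoxicity, read by sulforhodamine B assay, with a stated time of 72 h (on this read-out higher numbers stand for weaker inhibition and lower numbers for stronger inhibition), compound 1 `CCOC1Oc2ccccc2C(=O)/C1=C/Nc1ccc(S(N)(=O)=O)cc1` gives 22200 nM. Compound 3 `CCOC1Oc2ccccc2C(=O)/C1=C/Nc1ccc(S(=O)(=O)Nc2cc(C)on2)cc1`, which carries a 5-methyl-1,2-oxazol-3-yl group on the sulfonamide nitrogen, gives 25800 nM. The step of a 1.2-fold higher number from compound 1 to compound 3 (0.07 log units; within the scatter) shows that putting this ring onto the sulfonamide nitrogen left the read-out essentially where it was. Compound 2 `O=C1/C(=C/c2coc3ccccc3c2=O)N=C(c2ccccc2)N1c1ccc(S(=O)(=O)Nc2ccccn2)cc1`, built on a different core, gives > 100000 nM, which is a limit of this assay the limit of > 100000 nM in this assay, at which 1 of the 3 values shown sits, and not a number. Among the compounds with values here, of the two numbers known, compound 3 gives the highest one, though compound 1 sits within the scatter of it, so no order between the two can be claimed.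

Compound 4 `CCOC1Oc2ccccc2C(=O)/C1=C/Nc1ccc(S(=O)(=O)Nc2ncccn2)cc1` differs from compound 3 in one place: pyrimidin-2-yl in place of 5-methyl-1,2-oxazol-3-yl on a sulfonamide nitrogen. Within the data shown here, the only measured step that touches the sulfonamide nitrogen is the one from compound 1 to compound 3, and it moved the number within the scatter. Among the measured compounds shown here, no measured pair compares two different rings on that nitrogen, so the swap of one small aromatic ring for another of the same size gives no ground for expecting a large shift. The expected step of a 1.0-fold lower number from compound 3 to compound 4 (0.01 log units; within the scatter) is therefore small and of no clear direction. Compound 4 is estimated to give about 25000 nM, within a range from 10000 nM to 65000 nM.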

Compound 4, half-maximal inhibitory concentration: 30100 nM
Compound 4: middle estimate off by 1.2-fold (0.08 log units), on the low side; the measured number falls inside the stated range.
By their numbers in this assay, from the lowest: compounds 1, 3 and 4 (each within the scatter of the next). At a limit, above all of these: compound 2.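

Within the data shown here, compound 3 and compound 4 are the first measured pair with two different rings on the sulfonamide nitrogen, and in this assay the swap from a five-membered to a six-membered aromatic ring gives a 1.2-fold higher number from compound 3 to compound 4 (0.07 log units; within the scatter), so this pair separates the two rings no better than repeat measurements would. Replacing the hydrogen on that nitrogen with pyrimidin-2-yl gives a 1.4-fold higher number from compound 1 to compound 4 (0.13 log units; within the scatter), which makes this the second ring that cannot be told apart from the unsubstituted sulfonamide, so among compound 1, compound 3 and compound 4 this position has not yet shown any effect of what it carries. Nothing available bears on what lies behind this flat picture.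

Going by these compounds, all the groups seen on this nitrogen with the shared core are hydrogen or a small aromatic ring, so it remains open whether a carboxylic acid, an amine or a longer alkyl chain in that place would shift the number beyond the scatter. On these data alone, it also remains open whether replacing the ethoxy group of the shared core with an amine or a longer chain would matter more than any change on the sulfonamide nitrogen.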